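The source may report more compounds than this note shows. Statements on the series, on what has been measured and on what is new or still open speak of the compounds shown alone.

Measured so far in an assay on CHO cells for antagonist activity at transient receptor potential cation channel subfamily V member 1 (Homo sapiens), read by FLIPR; a lower number here means a stronger inhibitor, a higher number a weaker inhibitor: compound 1 `CCCN(CCC)c1cc(C(F)(F)F)ccc1CNC(=O)C(C)c1ccc(NS(C)(=O)=O)c(F)c1` gives 0.3 nM; compound 2 `CC(C(=O)NCc1ccc(C(F)(F)F)cc1N1CCC(C(F)(F)F)CC1)c1ccc(NS(C)(=O)=O)c(F)c1` gives 0.4 nM; compound 3 `CC(C)CCSc1cc(C(F)(F)F)ccc1CNC(=O)C(C)c1ccc(NS(C)(=O)=O)c(F)c1` gives 1.4 nM.

Compound 3 stands at the highest of the three numbers, with a 4.7-fold higher number from compound 1 to compound 3 (0.67 log units; beyond the scatter) and a 3.5-fold higher number from compound 2 to compound 3 (0.54 log units; beyond the scatter) both beyond the scatter, while a 1.3-fold higher number from compound 1 to compound 2 (0.12 log units; within the scatter) lies within it. Compound 4 `CC(C(=O)NCc1ccc(C(F)(F)F)cc1F)c1ccc(NS(C)(=O)=O)c(F)c1` differs from compound 3 by fluoro in place of isopentylsulfanyl on an aromatic carbon. Every measured step changes the group at this position, and all of them swap one sizeable group for another; none replaces such a group with a single atom. The measured steps therefore bear on the change only loosely, and compound 3 already marks the weaker end of the series. Compound 4 is expected to give a further rise in this assay, estimated as a 5.7-fold higher number from compound 3 to compound 4 (0.76 log units; beyond the scatter), to about 8 nM (range 2 nM to 40 nM).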

Compound 4, inhibition constant: 68.7 nM
Beside the measured number, compound 4's estimate is 8.6-fold (0.93 log units) below it, outside the stated range (above it).
By their numbers in this assay, from the lowest: compounds 1 and 2 (each within the scatter of the next); then compound 3; then compound 4.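

In this assay swaps among sizeable groups at this position had moved the number little or modestly, but reducing the group to a single fluoro gives a far larger rise, with a 49-fold higher number from compound 3 to compound 4 (1.69 log units; beyond the scatter) and a 170-fold higher number from compound 2 to compound 4 (2.23 log units; beyond the scatter) and also a 230-fold higher number from compound 1 to compound 4 (2.36 log units; beyond the scatter) as the result. Among these four compounds, the low numbers go with the three sizeable groups, whether attached through nitrogen or sulfur, and only compound 4 stands apart. Nothing shown gives a measured reason for this rise. The compounds shown leave open how the number runs between fluoro and the sizeable groups, as with a methoxy group or an ethyl chain. They also leave open whether a plain hydrogen here would behave like fluoro.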